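The compounds below may be only part of what the source reports. "The series", "measured", "known", "first", "only" and "open" are said of these compounds alone.

Among the measured compounds shown here, in a functional assay on MCF7 cells (Homo sapiens) for inhibition, read by MTT assay, with a stated time of 24 h (a lower number here means a stronger inhibitor of growth, a higher number a weaker inhibitor of growth), compound 1 `COc1cccc(C(=O)n2c(-c3cn(C)c4ccc(OC)cc34)nc3ccccc32)c1` gives 14600 nM, the higher of the two numbers so far. Compound 2 `COc1ccc2c(c1)c(-c1nc3ccccc3n1C(=O)c1ccc(OC)c(OC)c1)cn2C` gives 6300 nM. Compound 3 `COc1cccc(C(=O)n2c(-c3cn(C)c4ccc(Br)cc34)nc3ccccc32)c1` departs from compound 1 at one place: bromo in place of methoxy on an aromatic carbon. In short, this is bromo in place of methoxy on an aromatic carbon, in the part of the core that is a fused system of two rings.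

For the measured compounds named here, only one measured step is available, a 2.3-fold lower number from compound 1 to compound 2 (0.37 log units; beyond the scatter). It is modest, though beyond the scatter, and comes from methoxy in place of hydrogen on an aromatic carbon. Going by the values given here, that change lies at a different place from the one in compound 3, so it bears only indirectly and sets a rough scale, not a direction. Among the compounds with values here, no measured compound carries bromo, and none loses the methoxy in question. The expectation in this assay is therefore no step beyond the scatter, with wide uncertainty in either direction.

The estimated step is a 1.2-fold lower number from compound 1 to compound 3 (0.09 log units; within the scatter). For compound 3 the expected value is 12000 nM. The estimated range for compound 3 runs from 5000 nM to 30000 nM.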

Compound 3, concentration for 50% growth inhibition: 18200 nM
Beside the measured number, compound 3's estimate is 1.5-fold (0.18 log units) below it, within the range that was stated.
By their numbers in this assay, from the lowest: compound 2; then compounds 1 and 3 (each within the scatter of the next).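

In this assay, among the compounds shown here, the first reading at this position is a 1.2-fold higher number from compound 1 to compound 3 (0.10 log units; within the scatter), which lies within the scatter, so bromo and methoxy on this aromatic carbon of the fused system cannot be told apart in this read-out. The methoxy here is therefore not needed to keep the number at the level of compound 1, even though bromo brings no oxygen and one heavy atom fewer. For the compounds shown here, the only step beyond the scatter remains a 2.3-fold lower number from compound 1 to compound 2 (0.37 log units; beyond the scatter), at a different place on the molecule, and no information at hand accounts for the result at the new position.

Open, from the compounds shown here alone, is whether an amine, a hydroxyl or a longer chain such as ethoxy at this aromatic carbon would also stay level with compound 1, or whether any group here can move the number beyond the scatter. Going by these compounds alone, also open is whether the added methoxy that separates compound 2 from compound 1 would give a similar step on the bromo series, since the shared core has so far been read with only one such change at a time.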